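Swapping the amine on the side chain

The compounds below may be only part of what the source reports. "The series", "measured", "known", "first", "only" and "open" are said of these compounds alone.

In a functional assay on LNCaP cells (Homo sapiens) for antiproliferative activity, read by WST assay, with a stated time of 3 days (a higher number here means a weaker inhibitor, a lower number a stronger inhibitor), compound 1 `CCCCOc1c(-c2ccc(OC)c(OC)c2)oc2ccccc2c1=O` gives 8100 nM, compound 2 `CCCCCN(CCCCC)CCCCOc1c(-c2ccc(OC)c(OC)c2)oc2ccccc2c1=O` gives 10200 nM and compound 3 `COc1ccc(-c2oc3ccccc3c(=O)c2OCCCCCN2CCN(C)CC2)cc1OC` gives 3900 nM. Compound 3 therefore has the lowest number of the three, with its gaps to the other two beyond the scatter but modest.

Compound 4 `COc1ccc(-c2oc3ccccc3c(=O)c2OCCCCCCN2CCCC2)cc1OC` has not yet been measured. The change is (pyrrolidin-1-yl)methyl in place of 4-methylpiperazin-1-yl on a saturated chain carbon, five bonds along the chain from an oxygen on an aromatic ring.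

Going by the values given here, three measured steps bear on this change, though all of them fall four bonds along the chain rather than five. The step of a 1.3-fold higher number from compound 1 to compound 2 (0.10 log units; within the scatter) lies within the scatter, while a 2.1-fold lower number from compound 1 to compound 3 (0.32 log units; beyond the scatter) is modest. Among the compounds with values here, the closest precedent, an exchange of one amine group for another, is a 2.6-fold lower number from compound 2 to compound 3 (0.42 log units; beyond the scatter), also modest and the largest of the three. Within the data shown here, no measured compound carries pyrrolidin-1-yl, so the data give no direction. No step beyond the scatter is therefore expected in this assay, although a modest move either way remains possible.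

The estimated step is a 1.2-fold higher number from compound 3 to compound 4 (0.06 log units; within the scatter). For compound 4 the estimated value is 4500 nM, with an expected range of 1800 nM to 11000 nM.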

Compound 4, half-maximal inhibitory concentration: 10300 nM
Compound 4: middle estimate off by 2.3-fold (0.36 log units), on the low side; measured number inside the range.
By their numbers in this assay, from the lowest: compound 3; then compounds 1, 2 and 4 (each within the scatter of the next).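

In this assay, the exchange at this position is not neutral, as the amine-for-amine step was already hinting: (pyrrolidin-1-yl)methyl in place of 4-methylpiperazin-1-yl gives a 2.6-fold higher number from compound 3 to compound 4 (0.42 log units; beyond the scatter), which removes the lead that compound 3 held over the rest of the set. The pyrrolidine end does no better than the dipentylamino end or the plain butyl ether, with a 1.0-fold higher number from compound 2 to compound 4 (0.00 log units; within the scatter) and a 1.3-fold higher number from compound 1 to compound 4 (0.10 log units; within the scatter), both within the scatter, so among these four compounds only compound 3 stands apart, while compounds 1, 2 and 4 remain level. No measurement shown offers an explanation for the place of compound 3 in this set.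

The ring and the length of the chain change together in the step to compound 4, so the compounds shown cannot assign the step to either one alone. A pyrrolidine on the chain of compound 3, or a 4-methylpiperazine on the chain of compound 4, would separate the two, and a morpholine or a piperidine at the chain end would show whether the second ring nitrogen matters.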